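Three Aromatic Caps, One Value, a Fourth Awaited

This account rests on a few compounds, and the source may have more. Where it says the series, first, only, none or still open, it means among the compounds named here.

Compounds measured so far:
compound 1, `Cc1ccc(S(=O)(=O)NCc2ccc(CNC(=O)c3ccncc3)cc2)cc1`, which in an assay on MDA-MB-231 cells for binding affinity to C-X-C chemokine receptor type 4 (Homo sapiens), read by immunofluorescence and microscopy, with stated times of 10 min and 30 min (a higher number here means that more compound is needed for the effect, a lower number that less compound is needed), gives 10 nM
compound 2, `Cc1ccc(S(=O)(=O)NCc2ccc(CNC(=O)c3ccc(Cl)cc3)cc2)cc1`, which in this assay gives 10 nM
compound 3, `Cc1ccc(S(=O)(=O)NCc2ccc(CNC(=O)c3c(Cl)cc(Cl)cc3Cl)cc2)cc1`, which in this assay gives 10 nM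

All three share the same core and differ only in the aromatic group attached to the carbonyl carbon. Compound 3 stands level with compounds 1 and 2: no change at the digits printed from compound 1 to compound 3 (within the scatter) and no change at the digits printed from compound 2 to compound 3 (within the scatter), so none of the three can be called more or less active than another.

The next compound, compound 4, is `Cc1ccc(S(=O)(=O)NCc2ccc(CNC(=O)c3ccc([N+](=O)[O-])cc3)cc2)cc1`. Its difference from compound 3 is 4-nitrophenyl in place of 2,4,6-trichlorophenyl on a carbonyl carbon.

The measured steps that bear on this change are those that also swap the group on the carbonyl carbon: no change at the digits printed from compound 1 to compound 2 (within the scatter), no change at the digits printed from compound 1 to compound 3 (within the scatter) and no change at the digits printed from compound 2 to compound 3 (within the scatter). A pyridine ring, a lightly chlorinated ring and a heavily chlorinated ring all gave the same reading, which suggests this position tolerates quite different aromatic groups without a shift in this assay. Going by these compounds, a nitro-bearing ring is untested, so some caution is due.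

On that basis, compound 4 is expected to show no change at the digits printed from compound 3 to compound 4 (within the scatter), that is no step beyond the scatter. The estimate for compound 4 in this assay is 10 nM, with a range from 4 nM to 25 nM.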

Compound 4, effective concentration (reported as EC, without a stated level of effect): 10 nM
For compound 4 middle estimate and measured number coincide at the digits printed; the measured number falls inside the stated range.
By their numbers in this assay, from the lowest: compounds 1, 2, 3 and 4 (each within the scatter of the next).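

In this assay, 4-nitrophenyl in place of 2,4,6-trichlorophenyl on the carbonyl carbon gives no change at the digits printed from compound 3 to compound 4 (within the scatter), the replacement of pyridin-4-yl by 4-nitrophenyl gives no change at the digits printed from compound 1 to compound 4 (within the scatter), and nitro in place of chloro on an aromatic carbon gives no change at the digits printed from compound 2 to compound 4 (within the scatter). The new information is that tolerance at this place now extends to a group containing oxygen, with 2 hydrogen-bond acceptors where the departing 2,4,6-trichlorophenyl has 0, and with a double bond outside the aromatic ring, yet the reading stays level across all four compounds. No measurement is available that would explain this level reading.

For the compounds shown here, every group at this place so far is a six-membered aromatic ring, so it remains open whether a cyclohexyl ring, a longer carbon chain, or a ring carrying an amine or a carboxylic acid would also leave the reading level. Going by these compounds, with all four compounds level, it also remains open which group on the carbonyl carbon, if any, would move the reading beyond the scatter.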